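Compound 1 to compound 3: one hydroxy group capped

A few compounds are considered here, and "the series" means these few. Any claim that something is new, unique, unknown or untested is made for them only; others in the source may bear on it.

- compound 1 `C=C1C(=O)O[C@H]2[C@H]1[C@@H](OC(=O)/C(C)=C/C)C[C@@](C)(O)[C@]13C=C[C@](C)([C@H]21)[C@]1(C3)C(=O)O[C@@H]2[C@H]3C(C)=CC[C@H]3[C@](C)(O)C[C@H](O)[C@H]21` gives > 10000 nM in a functional assay on CNE-2 cells (Homo sapiens) for cytotoxicity, read by MTT assay, with a stated time of 48 h; on this read-out higher numbers stand for weaker inhibition and lower numbers for stronger inhibition (a limit)
- compound 2 `C=C1C(=O)O[C@H]2[C@H]1[C@@H](O)C[C@@](C)(O)[C@]13C=C[C@](C)([C@H]21)[C@]1(C3)C(=O)O[C@@H]2[C@H]3C(C)=CC[C@H]3[C@](C)(O)C[C@H](OC(=O)/C(C)=C\C)[C@H]21` gives > 10000 nM in this assay (a limit)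

Compound 1 has no exact place on the scale, since it stands at the limit of > 10000 nM in this assay, at which 2 of the 2 values shown sit, and that is a limit, not a number. Compound 3 `C=C1C(=O)O[C@H]2[C@H]1[C@@H](OC(=O)/C(C)=C/C)C[C@@](C)(O)[C@]13C=C[C@](C)([C@H]21)[C@]1(C3)C(=O)O[C@@H]2[C@H]3C(C)=CC[C@H]3[C@](C)(O)C[C@H](OC(=O)/C(C)=C/C)[C@H]21` keeps the core of compound 1 and differs in one place: (1-methylprop-1-en-1-yl)carbonyl in place of hydrogen on an oxygen on a saturated carbon. Here hydroxy becomes ((1-methylprop-1-en-1-yl)carbonyl)oxy, on a saturated carbon whose other neighbours are saturated ring carbon. Among the compounds with values here, no measured pair shows what this change does in this assay, so the expectation is modest: no gain in inhibition beyond the usual scatter, and a reading that probably stays at the limit. The expected change is a step that the limit leaves unreadable from compound 1 to compound 3, an estimate that rests on little. For compound 3 the estimated value is 15000 nM, with an expected range from 6000 nM to 40000 nM.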

Compound 3, half-maximal inhibitory concentration: 6000 nM
For compound 3 the middle estimate is 2.5-fold (0.40 log units) above the measured one; low and high end bracket the measured number.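

Capping the hydroxy group brings the series onto the measurable scale: in this assay, compound 3 gives an exact reading of 6000 nM, so an ester on this oxygen on a saturated carbon is compatible with a readable effect on these cells. Going from hydroxy to ((1-methylprop-1-en-1-yl)carbonyl)oxy gives an at least 1.6-fold lower number from compound 1 to compound 3 (0.22 log units; that floor lies within the scatter), so the size that can be vouched for is still no more than ordinary scatter. The real step may be larger, but it cannot be read because compound 1 stands at a limit and has no exact value: the limit of > 10000 nM in this assay, at which 2 of the 3 values shown sit.

On these data alone, what stays open is whether this particular unsaturated acyl group matters or whether any cap would do. A plain acetyl group, a longer saturated chain or an amine at this place would help to settle that.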